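The source may hold more compounds than are shown below. What is called first, only, known or untested is meant among the compounds shown, and "the series" means these compounds.

Measured compounds and values:

- compound 1, `COc1ccc(C(=O)c2ccc(OC)c3c2OC(C)(C)C=C3)c(NC(=O)CO)c1`: in a functional assay on HCT-8 cells (Homo sapiens) for antiproliferative activity, read by MTT assay, with a stated time of 48 h (a lower number here means a stronger inhibitor, a higher number a weaker inhibitor), compound 1 gives 230 nM
- compound 2, `COc1ccc(C(=O)c2ccc(OC)c3c2OC(C)(C)C=C3)c(NC(=O)CN)c1`: compound 2 gives 370 nM
- compound 3, `C=C(c1ccc(OC)cc1NC(=O)CO)c1ccc(OC)c2c1OC(C)(C)C=C2`: compound 3 gives 130 nM

Compound 4, `C=C(c1ccc(OC)cc1NC(=O)CN)c1ccc(OC)c2c1OC(C)(C)C=C2`, has not yet been measured in this assay.

Within the first pair the change is amino in place of hydroxy on a saturated chain carbon bound to a carbonyl carbon, and it produced a 1.6-fold higher number from compound 1 to compound 2 (0.21 log units; within the scatter). The same change, (amino in place of hydroxy on a saturated chain carbon bound to a carbonyl carbon), carries compound 3 to compound 4; the place lines of the two changes agree word for word, so this is the same change on a second core. How the core of compound 3 differs from the core of compound 1 is not broken down here.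

Compound 3 holds the lowest number of the three measured, though its gap to compound 1 lies within the scatter; only its gap to compound 2 lies beyond it.

Among the compounds with values here, for compound 4 the expectation rests on the one measured step, a 1.6-fold higher number from compound 1 to compound 2 (0.21 log units; within the scatter), and is that the step from compound 3 to compound 4 will be of comparable size, namely a 1.6-fold higher number from compound 3 to compound 4 (0.21 log units; within the scatter). Compound 4 is therefore estimated at 210 nM in this assay, expected to fall between 110 nM and 400 nM.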

Compound 4, half-maximal inhibitory concentration: 190 nM
Beside the measured number, compound 4's estimate is 1.1-fold (0.04 log units) above it; low and high end bracket the measured number.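

In this assay, amino in place of hydroxy on a saturated chain carbon bound to a carbonyl carbon gives a 1.5-fold higher number from compound 3 to compound 4 (0.16 log units; within the scatter), so on this second core too the step stays small. Within this pair of cores, the size of the step carries over with no readable difference: the same change on two cores in this assay, a 1.6-fold higher number (0.21 log units; within the scatter) from compound 1 to compound 2 and a 1.5-fold higher number (0.16 log units; within the scatter) from compound 3 to compound 4, 1.1-fold (0.04 log units) apart, within the scatter of two such steps. Within the data shown here, this shows only that the change behaves alike on the core of compound 1 and the core of compound 3; with both steps inside the scatter, it does not establish that amino truly raises the number over hydroxy, and two cores are no basis for a rule on any further core.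

The compounds shown leave open whether a larger departure at this place, such as a carboxylic acid, a dimethylamino group or a longer chain ending in an amine, would move the number beyond the scatter. Also open, as far as these compounds go, is whether the two steps would stay alike in another cell line.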